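Adding a hydroxy to the fused ring of a charged flavonol

A few compounds are considered here, and "the series" means these few. Any claim that something is new, unique, unknown or untested is made for them only; others in the source may bear on it.

Measured compounds:
compound 1, `O=c1c(OCCO)c(-c2ccc(O)c(O)c2)oc2ccccc12`, 600 nM
compound 2, `C[N+](C)(C)CCCOc1c(-c2ccc(O)c(O)c2)oc2ccccc2c1=O`, 1200 nM
compound 3, `C[N+](C)(C)CCCCCCCCOc1c(-c2ccc(O)c(O)c2)oc2ccccc2c1=O`, 1000 nM

All three were tested in a functional assay for inhibition, with Rattus norvegicus as the target, using microsomes; a higher number here means a weaker inhibitor, a lower number a stronger inhibitor. Compound 2 sits close to both others: the step of a 2.0-fold higher number from compound 1 to compound 2 (0.30 log units; within the scatter) and the step of a 1.2-fold lower number from compound 2 to compound 3 (0.08 log units; within the scatter) are each within the scatter, so these three numbers cannot be told apart with confidence. The change from compound 1 through compound 3 swaps the group at the chain end, and none of it moves the number beyond the scatter.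

Compound 4, `C[N+](C)(C)CCCOc1c(-c2ccc(O)c(O)c2)oc2cc(O)ccc2c1=O`, differs from compound 2 in one place: hydroxy in place of hydrogen on an aromatic carbon. The place is on an aromatic carbon of a six-membered aromatic ring of carbon only, part of a fused or bridged system of two rings. Within the data shown here, no measured step touches that ring, so nothing among the measured compounds bears directly on this change. With no guide either way, the expectation is no step beyond the scatter, no change at the digits printed from compound 2 to compound 4 (within the scatter). Compound 4 is therefore estimated at 1200 nM, within 500 nM to 3000 nM.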

Compound 4, half-maximal inhibitory concentration: 3800 nM
Beside the measured number, compound 4's estimate is 3.2-fold (0.50 log units) below it, outside the stated range (above it).
By their numbers in this assay, from the lowest: compounds 1, 3 and 2 (each within the scatter of the next); then compound 4.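

In this assay, the hydroxy in place of hydrogen on this aromatic carbon gives a 3.2-fold higher number from compound 2 to compound 4 (0.50 log units; beyond the scatter), a modest loss of inhibition. Among these compounds, the earlier compounds differed only in the group at the chain end, and none of those steps went beyond the scatter, so this is the first sign that the number responds to a change on the fused ring system, even one as small as a single heavy atom. Nothing available explains why the number rises with this change.

Going by these compounds, it remains open whether a methoxy group or a fluorine atom at this same place would shift the number as well, or whether a hydroxy on another carbon of this ring would do the same. On these data alone, it is also open whether this hydroxy would have a similar effect on compound 1 or on compound 3, which carry different chains.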